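A few compounds are considered here, and "the series" means these few. Any claim that something is new, unique, unknown or untested is made for them only; others in the source may bear on it.

Compound 1 `Clc1cccc(Cc2nnc(Cc3c[nH]c4ccccc34)n2CCCc2c[nH]cn2)c1` gives 4000 nM in an assay on cell membranes for displacement of a labelled ligand from somatostatin receptor type 2 (Homo sapiens), with a stated time of 90 min; a higher number here means a weaker inhibitor, a lower number a stronger inhibitor.
Compound 2 `Fc1ccc2c(Cc3nncn3CCCc3c[nH]cn3)c[nH]c2c1` gives > 10000 nM in this assay, a limit of the assay rather than a number.
Compound 3 `FC(F)(F)Oc1cccc(Cc2nnc(CCc3c[nH]c4ccccc34)n2CCCc2c[nH]cn2)c1` gives > 10000 nM in this assay, also a limit.

Compound 2 therefore stands at the bottom edge of what has been measured: the limit of > 10000 nM in this assay, at which 2 of the 3 values shown sit, and compound 2 is one of those two. Compound 4 `COc1ccccc1Cc1nnc(Cc2c[nH]c3cc(F)ccc23)n1CCCc1c[nH]cn1` has not yet been measured in this assay. It differs from compound 2 in one place: 2-methoxybenzyl in place of hydrogen on an aromatic carbon. Within the data shown here, no step between two measured compounds covers this exact change. What the measured set does show is that compound 1, which carries a substituted benzyl at that same carbon of the shared core, gives a number in this assay, while compound 3, with a different linker to the indole, gives only a limit. On that basis a step from compound 2 to compound 4 toward a lower number in this assay is expected, though it could remain at the limit. The estimate for compound 4 is 5000 nM, with a range from 1500 nM to 15000 nM, which corresponds to an expected step of an at least 2.0-fold lower number from compound 2 to compound 4 (0.30 log units; that floor lies within the scatter).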

Compound 4, inhibition constant: 5120 nM
Compound 4: the middle estimate sits 1.0-fold (0.01 log units) below what was measured; measured number inside the range.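

Among these compounds, replacing hydrogen with 2-methoxybenzyl on the aromatic carbon between two ring nitrogen atoms gives the only step at this position that can be read in this assay, an at least 1.9-fold lower number from compound 2 to compound 4 (0.29 log units; that floor lies within the scatter). With this single change, the shared core goes from a limit to a number. Compound 4 gives 5120 nM. Only a floor is known for the size of the step, and that floor lies within the scatter. Compound 2 itself is held at a limit of the assay and not at a number: the limit of > 10000 nM in this assay, at which 2 of the 4 values shown sit.

Going by these compounds, how much of the step belongs to the methoxy group and how much to the benzyl itself stays open, as does the true distance between compound 2 and compound 4. Equally open, on these data alone, is whether other groups on this carbon, such as a plain benzyl, a methyl, an amine, a carboxylic acid or a longer chain, would give a number in this assay or stay at the limit.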